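The compounds below may be only part of what the source reports. "The series", "measured", "known", "first", "only" and "open" are said of these compounds alone.

Of the compounds shown here, two of this set have been tested in an ADME assay on L929 cells (Mus musculus) for cytotoxicity, read by resazurin assay, with a stated time of 72 h; on this read-out lower numbers stand for stronger inhibition and higher numbers for weaker inhibition. Compound 1, `OB1OCc2ccc(-n3cc(Sc4ccc(O)cc4)c4ccccc43)cc21`, gives > 10 ug/mL, which is a limit of the assay rather than a measured number. Compound 2, `Cc1cccc(C(=O)c2ccn(-c3ccc4c(c3)B(O)OC4)c2)c1`, gives > 10 ug/mL in this assay, again a limit and not a number. Among the compounds with values here, compound 2 therefore stands level with compound 1 as far as the numbers go, since both readings sit at the limit of > 10 ug/mL in this assay, at which 2 of the 2 values shown sit, and no step between measured compounds can be drawn from them. Compound 3, `Nc1ccc(C(=O)c2ccn(-c3ccc4c(c3)B(O)OC4)c2)cc1`, has not yet been tested in this assay. It differs from compound 2 in one place: 4-aminophenyl in place of 3-methylphenyl on a carbonyl carbon. Within the data shown here, with both known readings at the limit, no measured step guides the expectation; the estimated step is a step that the limit leaves unreadable from compound 2 to compound 3, which amounts to nothing beyond the usual scatter. Compound 3 is accordingly expected to give about 15 ug/mL in this assay, within a range from 7 ug/mL to 40 ug/mL, and most likely to be reported again only as a limit.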

Compound 3, half-maximal inhibitory concentration: 3.9 ug/mL
Compound 3: middle estimate off by 3.8-fold (0.59 log units), on the high side; the whole stated range lies above it.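

The swap of 3-methylphenyl for 4-aminophenyl on a carbonyl carbon gives an at least 2.5-fold lower number from compound 2 to compound 3 (0.40 log units; beyond the scatter) in this assay. Within the data shown here, compound 3 is thus the first compound here to give a number rather than a limit, which shows that a change at this place alone can move the read-out towards stronger inhibition, something the earlier compounds could not show. The full size of the step stays unknown, and most of the values shown are still limits: the limit of > 10 ug/mL in this assay, at which 2 of the 3 values shown sit.

The pair changes the substituent and its place on the phenyl ring together, so it does not separate the gain of the amine from the loss of the methyl. On these data alone, whether a 3-aminophenyl, a 4-methylphenyl, a 4-hydroxyphenyl or an unsubstituted phenyl would give a number or a limit remains open.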